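The compounds below may be only part of what the source reports. "The series", "measured", "known", "first", "only" and "open" are said of these compounds alone.

In a functional assay on HL-60 cells (Homo sapiens) for inhibition, read by MTT assay, with a stated time of 72 h (on this read-out higher numbers stand for weaker inhibition and lower numbers for stronger inhibition), three compounds have been measured. Compound 1 `CCc1nc(-c2ccc(C(C)(C)C)cc2)c(C(=O)N2CCN(c3cccc(OC)c3)CC2)o1` gives "not active" (no number reported) in this assay. Compound 2 `Cc1nc(-c2ccccc2Cl)c(C(=O)N2CCN(c3cccc(Cl)c3)CC2)o1` gives 132 nM in this assay, and compound 3 `CCc1nc(-c2ccccc2Cl)c(C(=O)N2CCN(c3cccc(Cl)c3)CC2)o1` gives 98.9 nM in this assay. Going by the values given here, compounds 2 and 3 differ in one place, and the only measured step here, a 1.3-fold higher number from compound 3 to compound 2 (0.13 log units; within the scatter), lies within the scatter. The difference between the core of compound 1 and the core of compound 3 is not broken down here.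

Compound 4 `CCc1nc(-c2ccc(C(C)C)cc2)c(C(=O)N2CCN(c3cccc(OC)c3)CC2)o1` has not yet been measured. It differs from compound 1 by hydrogen in place of methyl on a saturated chain carbon bound to an aromatic carbon and two saturated chain carbons. The change from compound 3 to compound 2 is hydrogen in place of methyl on a saturated chain carbon bound to an aromatic carbon. Among the compounds shown this change occurs twice, and the two are the same kind of change, not the same: in compound 1 the carbon that loses the methyl is bound to an aromatic carbon and two saturated chain carbons, whereas in compound 3 it is bound to an aromatic carbon.

Among the compounds with values here, the one measured step of this kind, a 1.3-fold higher number from compound 3 to compound 2 (0.13 log units; within the scatter), lies within the scatter. On that basis the step from compound 1 to compound 4 is expected to be small. Compound 1 gives "not active" (no number reported) in this assay. Compound 4 is therefore expected to remain weak, estimated at 15000 nM in this assay, with an expected range from 2000 nM to 100000 nM.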

Compound 4, half-maximal inhibitory concentration: 887 nM
Compound 4: middle estimate off by 17-fold (1.23 log units), on the high side; the measured number lies below the stated range.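

No step can be read from compound 1 to compound 4 in this assay: compound 1 gives "not active" (no number reported), which is no number, while compound 4 gives 887 nM. The compounds shown leave open how large the change from tert-butyl to isopropyl is when both partners carry a number. No measured evidence here bears on this result.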